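Sulfonamide analogues: a pyridinyl to dimethylpyrimidinyl swap

A few compounds are considered here, and "the series" means these few. Any claim that something is new, unique, unknown or untested is made for them only; others in the source may bear on it.

Measured so far:
compound 1 `Cc1cc(NS(=O)(=O)c2ccc(N/C(S)=N\c3ccnc4cc(C(F)(F)F)ccc34)cc2)on1`: "not active" (no number reported)
compound 2 `O=S(=O)(Nc1ccccn1)c1ccc(N/C(S)=N\c2ccnc3cc(C(F)(F)F)ccc23)cc1`: 87500 nM

Going by the values given here, in a functional assay on LoVo cells (Homo sapiens) for antiproliferative activity, read by sulforhodamine B assay, with a stated time of 48 h (on this read-out lower numbers stand for stronger inhibition and higher numbers for weaker inhibition), compound 2 gives 87500 nM, the only number in this set, and compound 1 gave "not active" (no number reported) without any number. Compound 3 `Cc1cc(C)nc(NS(=O)(=O)c2ccc(N/C(S)=N\c3ccnc4cc(C(F)(F)F)ccc34)cc2)n1` differs from compound 2 in one place: 4,6-dimethylpyrimidin-2-yl in place of pyridin-2-yl on a sulfonamide nitrogen. Among the compounds with values here, no measured pair shows what such a change does, so the expected step is none beyond the scatter, although with compound 1 showing no activity a weaker outcome is also quite possible. Compound 3 is expected at 100000 nM, within the range 30000 nM to 300000 nM. The step of a 1.1-fold higher number from compound 2 to compound 3 (0.06 log units; within the scatter) is thus expected to stay within the scatter.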

Compound 3, half-maximal inhibitory concentration: 40200 nM
The estimate for compound 3 lay 2.5-fold (0.40 log units) above the measured number, and the stated range covers the measured number.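

Putting 4,6-dimethylpyrimidin-2-yl in place of pyridin-2-yl on the sulfonamide nitrogen gives, in this assay, a 2.2-fold lower number from compound 2 to compound 3 (0.34 log units; beyond the scatter). This first readable step shows that the group on this nitrogen can shift the result, here toward stronger inhibition, and that the larger ring is accepted. Nothing measured here explains the shift.

As far as these compounds go, the swap adds two methyl groups and a second ring nitrogen at once, so their separate contributions remain open. From the compounds shown here alone, whether a pyrimidin-2-yl ring without methyl groups, or a carboxylic acid on the ring, would change the number also remains open.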